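Swapping a piperidine for a chlorophenyl at the imide nitrogen

This account rests on a few compounds, and the source may have more. Where it says the series, first, only, none or still open, it means among the compounds named here.

Compound 3, `Cc1noc(-c2nc(C)c3c(c2N)C(=O)N(CC2CCNCC2)C3=O)n1`, has the highest value of the two full numbers in a physicochemical assay for solubility, using the shake flask method, in simulated intestinal fluid, measured as kinetic solubility, with a stated time of 2 h, at 25 degrees C, at pH 6.5; a lower number here means a less soluble compound, a higher number a more soluble compound: compound 3 gives 160000 nM. Compound 2, `CNC(=O)c1nc(C)c2c(c1N)C(=O)N(Cc1ccccc1)C2=O`, gives 41000 nM in this assay. Compound 1, `Cc1nc(C#N)c(N)c2c1C(=O)N(Cc1ccccc1)C2=O`, sits at a limit of this assay, < 5000 nM, and not at a measured number (the limit of < 5000 nM in this assay, at which 1 of the 3 values shown sits). Among the measured compounds shown here, the only measured step, an at least 8.2-fold higher number from compound 1 to compound 2 (0.91 log units; beyond the scatter), changes a group elsewhere on the shared core and does not touch the place that changes here, so no measured step bears directly on the present change.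

Compound 4 is `Cc1noc(-c2nc(C)c3c(c2N)C(=O)N(Cc2ccccc2Cl)C3=O)n1`. It differs from compound 3 by 2-chlorophenyl in place of piperidin-4-yl on a saturated chain carbon bound to an amide-type nitrogen in a ring. Compound 2 and compound 1 both carry a benzyl group at that same amide-type nitrogen, and their values lie well under that of compound 3, so a drop in this assay is expected for compound 4: an estimated step of a 20-fold lower number from compound 3 to compound 4 (1.30 log units; beyond the scatter). Compound 4 is therefore expected to give about 8000 nM, within 1500 nM to 40000 nM.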

Compound 4, solubility: < 5000 nM
Compound 4 gave a limit, no number; the forecaster's own chance of this, stated with the estimate: 30%; middle value at least 1.6-fold (0.20 log units) from the limit.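

Replacing piperidin-4-yl with 2-chlorophenyl on a saturated chain carbon bound to an amide-type nitrogen in a ring gives an at least 32-fold lower number from compound 3 to compound 4 (1.50 log units; beyond the scatter) in this assay. Compound 1 and compound 2 differ from compound 3 in more than one place and could only hint at the role of this position, whereas this pair differs at that position alone, and the large step shows that the group there matters in this assay. Compound 4 gives only a limit and not a number, and it shares that limit with compound 1: the limit of < 5000 nM in this assay, at which 2 of the 4 values shown sit.

The compounds shown leave open how far the step follows the ring nitrogen of the piperidine, the aromatic ring or the chlorine. A cyclohexyl group or a morpholin-4-yl group at the same place could help separate these parts of the change.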